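The compounds below may be only part of what the source reports. "The series", "measured", "known", "first", "only" and "open" are said of these compounds alone.

Measured so far:
compound 1 `COc1cccc(NC(=S)Nc2cccc(C(F)(F)F)c2)c1`: 52000 nM
compound 2 `CCNC(=S)Nc1cccc(C(F)(F)F)c1`: > 100000 nM

In an ADME assay on MDBK cells (Bos taurus) for cytotoxicity, read by MTT assay, with a stated time of 96 h (on this read-out higher numbers stand for lower toxicity in this test and lower numbers for higher toxicity in this test), compound 1 gives 52000 nM. For compound 2 the result is a limit of the assay, > 100000 nM. Compound 2 therefore stands at the limit of > 100000 nM in this assay, at which 1 of the 2 values shown sits. Compound 3 `C=C(C)CNC(=S)Nc1cccc(C(F)(F)F)c1` remains to be measured there. Its change against compound 2 is 1-methylethenyl in place of methyl on a saturated chain carbon bound to an amide-type nitrogen. Among the measured compounds shown here, no step between measured compounds is available to set a size, so the expected step, a number no higher from compound 2 to compound 3 (the limit leaves the size open), is none beyond the scatter. Compound 3 is thus estimated at 100000 nM, within 40000 nM to 250000 nM, with a limit rather than a number the more likely report.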

Compound 3, half-maximal cytotoxic concentration: > 100000 nM
Compound 3 gave a limit, no number; the forecaster's own chance of this, stated with the estimate: 60%; the middle value sits exactly at the limit.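

No step can be read between compound 2 and compound 3, since both results are limits of the assay: the limit of > 100000 nM in this assay, at which 2 of the 3 values shown sit.

On these data alone, whether 1-methylethenyl in place of methyl shifts cytotoxicity at all, and how far compound 2 and compound 3 lie past that limit, stays open.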